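This account rests on a few compounds, and the source may have more. Where it says the series, first, only, none or still open, it means among the compounds named here.

In a functional assay on MCF7 cells (Homo sapiens) for inhibition, read by radiometric assay and XTT assay (on this read-out lower numbers stand for stronger inhibition and higher numbers for weaker inhibition), compound 1 `C=C/C(C)=C/[C@@]1(C)SC(=O)C=C1O` returns only a limit of the assay, > 80 ug/mL. Real numbers exist for two compounds: compound 2 `CCCCCC[C@@]1(C)SC(=O)C=C1OCC(=O)OCC` gives 39.6 ug/mL and compound 3 `CCCCCCCC[C@@]1(C)SC(=O)C=C1OCC(=O)OCC` gives 35.3 ug/mL. These two values sit within the scatter of each other, so compound 2 stands level with compound 3.

Compound 4 `CCCCCC[C@@]1(C)SC(=O)C=C1OCC(=O)NCC(=O)O` differs from compound 2 at one place, with (carboxymethyl)amino in place of ethoxy on a carbonyl carbon. For the measured compounds named here, the only measured step, a 1.1-fold lower number from compound 2 to compound 3 (0.05 log units; within the scatter), puts ethyl in place of hydrogen on a saturated chain carbon. It touches a different part of the molecule, so it gives no real measure for this change.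

With so little to go on, only a modest move toward a higher number is expected, and the range must stay wide. A limit is also possible for compound 4, as with the limit of > 80 ug/mL in this assay, at which 1 of the 3 values shown sits. The expected change is a 1.5-fold higher number from compound 2 to compound 4 (0.18 log units; within the scatter). For compound 4 the estimated value is 60 ug/mL, with an expected range from 25 ug/mL to 130 ug/mL.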

Compound 4, half-maximal inhibitory concentration: > 80 ug/mL
Compound 4 gave a limit, no number; the forecaster's own chance of this, stated with the estimate: 40%; middle value at least 1.3-fold (0.12 log units) away from the limit.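

In this assay compound 4 gives only a limit of the assay, > 80 ug/mL. The earlier step changed only the saturated chain, whereas this one is the first change shown on the carbonyl carbon: (carboxymethyl)amino in place of ethoxy gives an at least 2.0-fold higher number from compound 2 to compound 4 (0.30 log units; that floor lies within the scatter). That size is only a floor and it lies within the usual scatter, so the result does not establish a real loss of inhibition, and the read-out gives no number for this compound, as with one other compound shown: the limit of > 80 ug/mL in this assay, at which 2 of the 4 values shown sit.

The compounds shown leave open which part of the new group counts, the amide nitrogen or the carboxylic acid it carries. A plain ethylamino group in place of ethoxy, or a free carboxylic acid on the same carbonyl carbon, would separate these two parts.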